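Chloro in place of methoxy on an aromatic carbon

The compounds below may be only part of what the source reports. "The series", "measured", "known", "first", "only" and "open" are said of these compounds alone.

In a functional assay on MDA-MB-435 cells (Homo sapiens) for antiproliferative activity, read by CellTiter-Glo, with a stated time of 96 h (on this read-out higher numbers stand for weaker inhibition and lower numbers for stronger inhibition), compound 1 `COc1ccc(-c2nsc3c2NC(=O)CC3c2cccc(OC)c2)cc1` gives 591 nM and compound 2 `COc1ccc(-c2nsc3c2NC(=O)CC3c2ccc3c(c2)OCCO3)cc1` gives 349 nM. Going by the values given here, these two numbers lie within the scatter of each other, so compound 1 stands level with the only other compound measured so far. Compound 3 `COc1ccc(-c2nsc3c2NC(=O)CC3c2cccc(Cl)c2)cc1` keeps the core of compound 1 and differs from it in one place: chloro in place of methoxy on an aromatic carbon. This is chloro in place of methoxy on an aromatic carbon, meta to a large group. Among the compounds with values here, no measured pair of compounds differs in one place only, so the data offer no direct guide to this change. The expected change in this assay, a 1.2-fold lower number from compound 1 to compound 3 (0.07 log units; within the scatter), is none beyond the scatter, and no direction is favoured. Compound 3 is estimated at 500 nM, with an expected range of 170 nM to 1500 nM.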

Compound 3, half-maximal inhibitory concentration: 792 nM
The estimate for compound 3 lay 1.6-fold (0.20 log units) below the measured number; low and high end bracket the measured number.
By their numbers in this assay, from the lowest: compounds 2, 1 and 3 (each within the scatter of the next, the first and the last beyond it).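

In this assay, going by these compounds alone, the exchange of 3-methoxyphenyl for 3-chlorophenyl gives the first step that can be read at a single place, a 1.3-fold higher number from compound 1 to compound 3 (0.13 log units; within the scatter) and this step leaves the two compounds level. At this aromatic carbon, meta to a large group, the methoxy can thus give way to chloro, with one heavy atom fewer and the oxygen gone, without a change beyond the scatter. No measurement at hand says why the read-out holds level across this change.

The compounds shown leave open whether an amine, a carboxylic acid or a longer chain such as ethoxy on this same carbon would also stay level with compound 1 or would move the number beyond the scatter. Also open, from the compounds shown here alone, is whether chloro in place of the methoxy on the other aromatic ring would read the same way.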